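This account rests on a few compounds, and the source may have more. Where it says the series, first, only, none or still open, it means among the compounds named here.

Working notes on the series in a functional assay on HeLa cells (Homo sapiens) for inhibition, read by MTT assay, with a stated time of 48 h (on this read-out higher numbers stand for weaker inhibition of growth and lower numbers for stronger inhibition of growth), follow. Compound 1 (`COc1ccc(C2=NN(C(=O)c3ccncc3)C(c3cn(C)c4ccc(Br)cc34)C2)cc1OC`) stands at > 10000 nM in this read-out, and that is a limit of the assay, not a number. Compound 2 (`COc1ccc2c(c1)c(C1CC(c3ccccc3)=NN1C(=O)c1cccnc1)cn2C`) gives 3590 nM as a measured number. Compound 3 (`COc1cccc(C2=NN(C(=O)c3cccnc3)C(c3cn(C)c4ccc(OC)cc34)C2)c1`) gives 1270 nM and so holds the lower of the two actual numbers, with compound 2 as its nearest neighbour.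

The change to compound 4 (`COc1cccc(C2=NN(C(=O)c3ccc(C)nc3)C(c3cn(C)c4ccc(OC)cc34)C2)c1`) is methyl in place of hydrogen on an aromatic carbon and it turns pyridin-3-yl into 6-methylpyridin-3-yl. Among the compounds with values here, no measured step touches this ring. Within the data shown here, compound 1 differs from compound 3 in more than one place and offers no step. Among the measured compounds shown here, the only guide is the modest step (a 2.8-fold lower number from compound 2 to compound 3 (0.45 log units; beyond the scatter)) from methoxy in place of hydrogen on an aromatic carbon elsewhere in the molecule. On these data alone, it is a weak analogy, so no step beyond the scatter is expected in this assay and the direction stays open. The expected step is a 1.2-fold lower number from compound 3 to compound 4 (0.06 log units; within the scatter) on this estimate. For compound 4 the estimated value is 1100 nM with an expected range from 400 nM to 3500 nM in this read-out.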

Compound 4, concentration for 50% growth inhibition: 34 nM
Compound 4: middle estimate off by 32-fold (1.51 log units), on the high side; the measured number lies below the stated range.
By their numbers in this assay, from the lowest: compound 4; then compound 3; then compound 2. At a limit, above all of these: compound 1.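

In this assay, within the data shown here, methyl in place of hydrogen on an aromatic carbon of the pyridine ring, next to the ring nitrogen and para to a large group, gives a 37-fold lower number from compound 3 to compound 4 (1.57 log units; beyond the scatter) and shows that this ring, which no earlier single-place step touched, is a highly sensitive part of the series in this read-out. Among these compounds, the addition of one carbon here counts for far more than the only earlier single-place change, a methoxy group elsewhere in the molecule, which gave a 2.8-fold lower number from compound 2 to compound 3 (0.45 log units; beyond the scatter) and so offered no sign of a change of this size. Nothing measured in the series accounts for the size of the step from hydrogen to methyl.

Among the compounds shown here, whether the gain is particular to methyl remains open, since a longer chain such as ethyl, a fluorine atom or an amine on the same carbon could keep, extend or lose it, and hydrogen and methyl are the only two groups compared there. Also open, on these data alone, is whether 6-methylpyridin-3-yl gives a similar step on the core of compound 2, or whether the step depends on the methoxy group that compound 3 and compound 4 share.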